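Propyl to ethyl on two pyrazole cores: hydroxamic acids

The source may report more compounds than this note shows. Statements on the series, on what has been measured and on what is new or still open speak of the compounds shown alone.

Measured compounds:
compound 1 `CCCc1cc(-c2ccc(F)cc2)nn1Cc1ccc(C(=O)NO)cc1` 107 nM
compound 2 `CCc1cc(-c2ccc(F)cc2)nn1Cc1ccc(C(=O)NO)cc1` 35 nM
compound 3 `CCCc1cc(-c2ccc(F)cc2)n(Cc2ccc(C(=O)NO)cc2)n1` 167 nM

In an assay on cells for inhibition of protein deacetylase HDAC6 (Homo sapiens), read by fluorescence, with stated times of 15 min and 60 min (on this read-out lower numbers stand for stronger inhibition and higher numbers for weaker inhibition), compound 1 gives 107 nM, while compound 2 gives 35 nM. The step between them is hydrogen in place of methyl on a saturated chain carbon, two bonds along the chain from an aromatic carbon, and it reads a 3.1-fold lower number from compound 1 to compound 2 (0.49 log units; beyond the scatter). Compound 3 shares its atoms with compound 1 but joins them differently; the difference between the two cores is not broken down here. In this assay compound 3 gives 167 nM, the highest number of the three.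

Compound 4 `CCc1cc(-c2ccc(F)cc2)n(Cc2ccc(C(=O)NO)cc2)n1` is not yet measured. It relates to compound 3 by hydrogen in place of methyl on a saturated chain carbon, two bonds along the chain from an aromatic carbon, the same change as from compound 1 to compound 2. Among the compounds with values here, on the core of compound 3 the step is expected to be a 2.8-fold lower number from compound 3 to compound 4 (0.44 log units; beyond the scatter), resting on the one earlier step of a 3.1-fold lower number from compound 1 to compound 2 (0.49 log units; beyond the scatter), with widened spread because only one instance is known. Compound 4 is therefore estimated at 60 nM, between 25 nM and 150 nM.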

Compound 4, half-maximal inhibitory concentration: 69 nM
For compound 4 the middle estimate is 1.2-fold (0.06 log units) below the measured one; the measured number falls inside the stated range.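

Propyl to ethyl also lowers the number on the second core in this assay, with a 2.4-fold lower number from compound 3 to compound 4 (0.38 log units; beyond the scatter). Set beside the earlier step, the two instances agree: the same change on two cores in this assay, a 3.1-fold lower number (0.49 log units; beyond the scatter) from compound 1 to compound 2 and a 2.4-fold lower number (0.38 log units; beyond the scatter) from compound 3 to compound 4, 1.3-fold (0.10 log units) apart, within the scatter of two such steps. The change therefore carries across these two cores in this assay, but two instances do not show that it would carry to other cores or to other assays, and they do not explain why the number moves.

Open, from the compounds shown here alone, is whether a methyl or a longer chain such as butyl in place of the propyl would extend the same direction on both cores. Also open, going by these compounds, is how an amine or a carboxylic acid at the end of that chain would read.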